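The source may hold more compounds than are shown below. What is called first, only, known or untested is meant among the compounds shown, and "the series" means these compounds.

Compound 1 `COc1cc(C)cc(-c2c(-c3ccnc(-c4ccc(C(C)=O)cc4)c3)cnn2CC#N)c1` sits in a small set of three close relatives, all of which share one core and differ only at the outer edges. In a functional assay on BT-549 cells (Homo sapiens) for cytotoxicity, read by sulforhodamine B assay, with a stated time of 48 h, tested at 0.01 uM (a higher number here means a weaker effect of the compound at the concentration tested, a lower number a stronger effect), compound 1 gives 86%, the lowest of the three numbers. Compound 3 `Cc1cc(O)cc(-c2nn(CC#N)cc2-c2ccnc(-c3ccc(N(C)C)cc3)c2)c1` gives 91%, within the scatter of compound 1, while compound 2 `COc1cc(C)cc(-c2nn(CC#N)cc2-c2ccnc(-c3ccc(N(C)C)cc3)c2)c1` gives 100%, which stands beyond the scatter above compound 1. For the measured compounds named here, the one step with a single change, a number 9 percentage points lower from compound 2 to compound 3 (within the scatter), stays within the scatter.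

Compound 4 `COc1cc(C)cc(-c2c(-c3ccnc(-c4ccc(N(C)C)cc4)c3)cnn2CC#N)c1` is reached from compound 1 by a change at the far end of the molecule: dimethylamino in place of acetyl on an aromatic carbon. Going by the values given here, no measured step isolates this exchange, so the only guide is that compound 2, which also carries dimethylamino, gives a higher number than compound 1. A modest rise is therefore expected, with wide uncertainty, amounting to a number 9 percentage points higher from compound 1 to compound 4 (within the scatter). Compound 4 is estimated at 95%, with a range from 82% to 105%.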

Compound 4, a percentage reported as activity, at one concentration (the size of the read-out at that concentration, not a potency): 44%
Compound 4: the middle estimate sits 51 percentage points above what was measured; measured number outside the range, below it.
By their numbers in this assay, from the lowest: compound 4; then compounds 1, 3 and 2 (each within the scatter of the next, the first and the last beyond it).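

For the compounds shown here, the far end of the molecule turns out to matter in this assay: the exchange of acetyl for dimethylamino on the aromatic carbon gives a number 42 percentage points lower from compound 1 to compound 4 (beyond the scatter), the first large step in this set, whereas the earlier single change at the other edge stayed within the scatter. The two groups match in heavy-atom count, and each has one hydrogen-bond acceptor and no donor, so these counts do not separate them. Nothing measured here accounts for the size of this step.

As far as these compounds go, it remains open how other groups at this position, such as a primary amine, a carboxylic acid or a pyrrolidine ring, would fall relative to dimethylamino and acetyl. With a read-out taken at a single concentration, the step also gives the size of the effect at that concentration, not a difference in potency.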